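Taking One Fluoro Group Away from Compound 2

This account rests on a few compounds, and the source may have more. Where it says the series, first, only, none or still open, it means among the compounds named here.

In an ADME assay on liver for metabolic stability, with Liver microsome (Homo sapiens) as the target, using microsomes, with a stated time of 10 min, tested at 0.5 uM (a higher number here means that more of the compound is left, a lower number that less of the compound is left), compound 1 `Cc1noc(C)c1[C@@H]1C[C@@](C)(c2cc(NC(=O)c3ccc(Cl)cn3)c(F)cc2F)N=C(N)S1` gives 78% and compound 2 `Cc1noc(C)c1[C@@H]1C[C@@](C)(c2cc(NC(=O)c3ccc(Cl)cn3)cc(F)c2F)N=C(N)S1` gives 87% as its reading. For the measured compounds named here, these are the only two numbers available so far, and they lie within the scatter of each other, so compound 2 cannot be told apart from compound 1 on this measure.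

Compound 3 `Cc1noc(C)c1[C@@H]1C[C@@](C)(c2cc(F)cc(NC(=O)c3ccc(Cl)cn3)c2)N=C(N)S1` has not yet been measured. It differs from compound 2 by a single change hydrogen in place of fluoro on an aromatic carbon in which hydrogen stands in place of fluoro on an aromatic carbon, para to a ((5-chloropyridin-2-yl)carbonyl)amino group. Going by the values given here, no measured pair shows what this change does. Among the compounds with values here, the readings of compound 1 at 78% and compound 2 at 87% are the only guide, and on that basis only a small downward step, not beyond the scatter, is expected in this assay for this change. The expected move is a number 7 percentage points lower from compound 2 to compound 3 (within the scatter) and so would stay within the scatter. The estimate for compound 3 is 80% with an expected range of 65% to 93% in this assay once it is measured.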

Compound 3, percent of the compound remaining: 39%
Beside the measured number, compound 3's estimate is 41 percentage points above it, outside the stated range (below it).
By their numbers in this assay, from the lowest: compound 3; then compounds 1 and 2 (each within the scatter of the next).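

Hydrogen in place of fluoro on this aromatic carbon brings a number 48 percentage points lower from compound 2 to compound 3 (beyond the scatter) in this assay, so the reading proves highly sensitive to what stands at this one place, ortho to a fluoro group and para to a ((5-chloropyridin-2-yl)carbonyl)amino group. The earlier compounds shown here could not show this: their two readings lay within the scatter of each other, and no step between compounds differing in one place was yet available. Nothing at hand bears on the mechanism behind this large step.

From the compounds shown here alone, whether the drop follows from the loss of fluoro specifically, or whether other groups on this carbon would hold the reading near that of compound 2, stays open, as a chloro group, a methyl group or a methoxy group there would help to tell. Also open, going by these compounds, is whether replacing the remaining fluoro group of compound 3 with hydrogen would move the reading further in this assay, or whether this aromatic carbon is the only place on the ring where such a change matters so much.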